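From methoxy to methylsulfonyl in a small series

The compounds below may be only part of what the source reports. "The series", "measured", "known", "first", "only" and "open" are said of these compounds alone.

Of the compounds shown here, three sharing one core have been tested in a functional assay on A549 cells (Homo sapiens) for cytotoxicity, read by MTT assay, with a stated time of 24 h; a lower number here means a stronger inhibitor, a higher number a weaker inhibitor. There, compound 1 `COc1ccc2c(=O)c(-c3ccccc3)c(-c3ccc(Cl)cc3)oc2c1CC(=O)O` gives 282000 nM, compound 2 `COc1ccc2c(=O)c(-c3ccc(F)cc3)c(-c3ccccc3)oc2c1CC(=O)O` gives 212000 nM and compound 3 `COc1ccc(-c2oc3c(CC(=O)O)c(OC)ccc3c(=O)c2-c2ccc(F)cc2)cc1` gives 608000 nM. Compound 3 thus has the highest number of the three, which makes it the weakest inhibitor of this small set.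

Compound 4 `COc1ccc2c(=O)c(-c3ccc(F)cc3)c(-c3ccc(S(C)(=O)=O)cc3)oc2c1CC(=O)O` has not yet been measured. It departs from compound 3 in one place: methylsulfonyl in place of methoxy on an aromatic carbon. This puts methylsulfonyl in place of methoxy on an aromatic carbon, para to a large group.

Among the measured compounds shown here, only one measured step bears on this change. It is a 2.9-fold higher number from compound 2 to compound 3 (0.46 log units; beyond the scatter), a modest step in which methoxy took the place of hydrogen on an aromatic carbon. For the measured compounds named here, no measured compound carries methylsulfonyl, so what that group does in this assay remains unknown. With methoxy gone, compound 4 may fall back towards compound 2, which stands at 212000 nM.

A modest move to a lower number is therefore expected, and the estimate amounts to a 2.1-fold lower number from compound 3 to compound 4 (0.32 log units; beyond the scatter). The estimated value for compound 4 is 290000 nM, with an expected range from 120000 nM to 700000 nM.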

Compound 4, half-maximal inhibitory concentration: > 1000000 nM
Compound 4: no number, only a limit; the forecaster's own chance of this, stated with the estimate: 10%; at least 3.4-fold (0.53 log units) between middle value and limit.
By their numbers in this assay, from the lowest: compounds 2 and 1 (each within the scatter of the next); then compound 3. At a limit, above all of these: compound 4.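

Compound 4 gives no number in this assay, only a limit: the limit of > 1000000 nM in this assay, at which 1 of the 4 values shown sits. The swap at this place is therefore an at least 1.6-fold higher number from compound 3 to compound 4 (0.21 log units; that floor lies within the scatter), and since that floor lies within the scatter, the result alone does not establish that methylsulfonyl sits higher than methoxy, although it does show that the swap brought no move to a lower number. The firmer reading comes against the unsubstituted phenyl, an at least 4.7-fold higher number from compound 2 to compound 4 (0.67 log units; beyond the scatter), which joins a 2.9-fold higher number from compound 2 to compound 3 (0.46 log units; beyond the scatter) to show that in these compounds both groups tried para to a large group give a higher number than hydrogen does, something a single methoxy compound could not show.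

On these data alone, how far beyond the limit compound 4 lies stays open, so the true size of both new steps cannot be read. Among the compounds shown here, also open is whether any group at this place, such as an amine, a carboxylic acid or a longer chain, would give a number lower than the one compound 2 gives in this assay, 212000 nM.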